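A few compounds are considered here, and "the series" means these few. Any claim that something is new, unique, unknown or untested is made for them only; others in the source may bear on it.

Compound 1, `Cc1ccc(N/C(=N\C(=O)c2ccccc2)NCc2ccccc2)cc1`: 876000 nM
Compound 2, `COc1ccc(N/C(=N\C(=O)c2ccccc2)NCc2ccccc2)cc1`: 837000 nM
Compound 3, `O=C(/N=C(/NCc1ccccc1)Nc1ccc(C(F)(F)F)cc1)c1ccccc1`: 18600 nM

In an ADME assay on cells (Peritoneal macrophage, Mus musculus) for cytotoxicity, read by MTT assay, with a stated time of 24 h (a higher number here means that more compound is tolerated, a lower number that less compound is tolerated), compound 2 stands second highest of the three numbers: compound 1 sits within the scatter of it, a 1.0-fold lower number from compound 1 to compound 2 (0.02 log units; within the scatter), while compound 3 lies far beneath it, a 45-fold lower number from compound 2 to compound 3 (1.65 log units; beyond the scatter). Compound 4, `O=C(/N=C(/NCc1ccccc1)Nc1ccc([N+](=O)[O-])cc1)c1ccccc1`, has not yet been measured in this assay; it differs from compound 2 by nitro in place of methoxy on an aromatic carbon. Going by the values given here, the steps that bear on this are the two large drops at the same aromatic carbon, a 45-fold lower number from compound 2 to compound 3 (1.65 log units; beyond the scatter) and a 47-fold lower number from compound 1 to compound 3 (1.67 log units; beyond the scatter), though no measured step exchanges methoxy for nitro itself. A lower number for compound 4 in this assay is therefore expected, with the step of a 14-fold lower number from compound 2 to compound 4 (1.14 log units; beyond the scatter) estimated, and compound 4 is expected to give about 60000 nM, in a range from 15000 nM to 400000 nM.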

Compound 4, half-maximal cytotoxic concentration: 802000 nM
Compound 4: the middle estimate sits 13-fold (1.13 log units) below what was measured; measured number outside the range, above it.
By their numbers in this assay, from the lowest: compound 3; then compounds 4, 2 and 1 (each within the scatter of the next).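

At this position, moving away from methyl or methoxy does not in itself bring a lower number in this assay: nitro gives a 1.0-fold lower number from compound 2 to compound 4 (0.02 log units; within the scatter) and a 1.1-fold lower number from compound 1 to compound 4 (0.04 log units; within the scatter), so these three groups cannot be told apart here. Trifluoromethyl alone stands apart among the compounds shown, with a 43-fold higher number from compound 3 to compound 4 (1.63 log units; beyond the scatter) as the step back to nitro. Nothing measured here accounts for this separation.

The compounds shown leave open whether an amine, a carboxylic acid or a chlorine atom at this position would fall with compound 3 or with the other three compounds. They also leave open whether trifluoromethyl would give a similar step on a different core.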